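Lengthening the Amide Acyl Group from Acetyl to Propanoyl

This account rests on a few compounds, and the source may have more. Where it says the series, first, only, none or still open, it means among the compounds named here.

Compound 1, `Nc1nc(CN=C=S)c[se]1`: 21000 nM in a functional assay on L1210 cells (Mus musculus) for antiproliferative activity; on this read-out higher numbers stand for weaker inhibition and lower numbers for stronger inhibition
Compound 2, `CC(=O)Nc1nc(CN=C=S)c[se]1`: 30000 nM in this assay

Compound 2 and compound 1 lie within the usual scatter of each other, the step of a 1.4-fold higher number from compound 1 to compound 2 (0.15 log units; within the scatter) being small. Compound 3, `CCC(=O)Nc1nc(CN=C=S)c[se]1`, differs from compound 2 by methyl in place of hydrogen on a saturated chain carbon bound to a carbonyl carbon. Going by the values given here, only one measured step, a 1.4-fold higher number from compound 1 to compound 2 (0.15 log units; within the scatter), bears on this change, and it stayed within the scatter. For compound 3 a step of no change at the digits printed from compound 2 to compound 3 (within the scatter) is therefore expected, none beyond the scatter. Compound 3 is estimated at 30000 nM, with a range from 12000 nM to 75000 nM.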

Compound 3, half-maximal inhibitory concentration: 3500 nM
Estimate against measurement, compound 3: 8.6-fold (0.93 log units) above, and the stated range ends above it.
By their numbers in this assay, from the lowest: compound 3; then compounds 1 and 2 (each within the scatter of the next).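

In this assay the added methyl on the saturated chain carbon bound to a carbonyl carbon gives an 8.6-fold lower number from compound 2 to compound 3 (0.93 log units; beyond the scatter) and so shows that this position responds to a change as small as acetyl to propanoyl. Propanoyl in place of hydrogen on the nitrogen gives a 6.0-fold lower number from compound 1 to compound 3 (0.78 log units; beyond the scatter) and thus passes beyond the scatter, which acetyl there did not. Nothing given here explains this drop.

As far as these compounds go, whether a longer chain such as butanoyl lowers the number further remains open. So does whether a branched isobutyryl or a ring-bearing benzoyl group would behave like propanoyl.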